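The source may hold more compounds than are shown below. What is called first, only, known or untested is meant among the compounds shown, and "the series" means these compounds.

Of the compounds shown here, two have been tested in a functional assay on MGC-803 cells (Homo sapiens) for antiproliferative activity, read by CCK-8 assay, with a stated time of 72 h, tested at 2 uM; on this read-out lower numbers stand for a weaker effect and higher numbers for a stronger effect at the one concentration tested. Compound 1 `Nc1ccccc1NC(=O)c1ccc(CSC(=S)N2CCN(c3ccc(Cl)cc3)CC2)cc1` gives 15% in this assay, the lower of the two numbers seen so far. Among the compounds with values here, compound 2 `Nc1ccccc1NC(=O)c1ccc(CSC(=S)N2CCc3ccccc32)cc1` gives 44% in this assay, a number that sits beyond the usual scatter above compound 1; no step between these two compounds has been worked out, so only their two values speak. Compound 3 `Nc1ccccc1NC(=O)c1ccc(CSC(=S)N2CCN(c3cnccn3)CC2)cc1` has not yet been measured. It differs from compound 1 in one place: pyrazin-2-yl in place of 4-chlorophenyl on an amine nitrogen in a ring. Within the data shown here, with no measured step of this kind to draw on, the step of a number 2 percentage points higher from compound 1 to compound 3 (within the scatter) is expected to be small, in neither direction beyond the scatter of repeated measurements. For compound 3, the value in this assay is therefore estimated at 17%, within a range from 2% to 38%.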

Compound 3, a percentage reported as inhibition, at one concentration (the size of the read-out at that concentration, not a potency): 27.1%
The estimate for compound 3 lay 10.1 percentage points below the measured number; the measured number falls inside the stated range.
By their numbers in this assay, from the lowest: compound 1; then compound 3; then compound 2.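

In this assay, within the data shown here, the swap of 4-chlorophenyl for pyrazin-2-yl on the amine nitrogen of the six-membered ring gives the first measured step at this position, a number 12.1 percentage points higher from compound 1 to compound 3 (beyond the scatter). The value therefore responds to the choice of aromatic ring at this place, and a ring with 2 hetero atoms is accepted here, with a modest gain over the carbon-only ring. Among these compounds, nothing measured so far explains this gain.

This single pair cannot separate the effect of removing the chlorine from that of adding the ring nitrogens; an unsubstituted phenyl or a pyridin-2-yl group at the same place would help to tell them apart. A reading at one concentration also leaves the potency of both compounds open.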